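Working notes on an aromatic substituent swap

The source may hold more compounds than are shown below. What is called first, only, known or untested is meant among the compounds shown, and "the series" means these compounds.

Measured so far:
compound 1 `C=CC[C@H]1C[C@]2([C@@H](C)Cc3cccc(OC)c3)OCOC2=CC1=O`: 10600 nM in a functional assay on NCI-H460 cells (Homo sapiens) for antiproliferative activity, with a stated time of 72 h; on this read-out higher numbers stand for weaker inhibition and lower numbers for stronger inhibition
compound 2 `C=CC[C@H]1C[C@]2([C@@H](C)Cc3ccc(OC)c(C(=O)NC)c3)OCOC2=CC1=O`: 1100 nM in this assay

Compound 2 shows the lowest of the two numbers; compound 1 sits a good deal higher on this read-out, and the gap between them lies beyond the scatter. Among the compounds with values here, no single-point step links the two, so the pair is noted only for what the values show.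

Compound 3 `C=CC[C@H]1C[C@]2([C@@H](C)Cc3ccc(OC)c(F)c3)OCOC2=CC1=O` has not been measured. It differs from compound 2 in one place: fluoro in place of methylcarbamoyl on an aromatic carbon. Compound 1, which also lacks the methylcarbamoyl, gives the weaker value 10600 nM; on that basis compound 3 is expected to move toward weaker inhibition, though the comparison is not a clean one. The expected step of a 3.6-fold higher number from compound 2 to compound 3 (0.56 log units; beyond the scatter) is a modest loss, beyond the scatter. Compound 3 is estimated at 4000 nM, with a range of 1500 nM to 12000 nM in this assay.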

Compound 3, half-maximal inhibitory concentration: 90 nM
For compound 3 the middle estimate is 44-fold (1.65 log units) above the measured one; measured number outside the range, below it.
By their numbers in this assay, from the lowest: compound 3; then compound 2; then compound 1.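

In this assay, fluoro in place of methylcarbamoyl on the aromatic carbon ortho to a methoxy group gives a 12-fold lower number from compound 2 to compound 3 (1.09 log units; beyond the scatter), a large step toward stronger inhibition. This position therefore does not need the methylcarbamoyl group for the stronger inhibition seen here, and a much smaller group with no hydrogen-bond donor or acceptor serves better in this series. No measurement shown bears on what lies behind the size of this step.

The compounds shown leave open whether the gain belongs to fluoro itself or simply to the loss of methylcarbamoyl. A compound carrying hydrogen, chloro or a nitrile on this carbon, with the methoxy group and the rest of compound 3 kept, would separate the two readings.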